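This account rests on a few compounds, and the source may have more. Where it says the series, first, only, none or still open, it means among the compounds named here.

Of the compounds shown here, two built on a shared core have been tested in an assay on a protein complex (Cavia porcellus) with sulfonylurea receptors; K-ATP channels (Homo sapiens) as the target (a lower number here means a stronger inhibitor, a higher number a weaker inhibitor), and a third is about to be. Compound 1, with the structure `CC(O)(C(=O)Nc1ccc(/C(=N\O)c2ccccc2)cc1)C(F)(F)F`, gives > 30000 nM in this assay; that is the limit of > 30000 nM in this assay, at which 1 of the 2 values shown sits, a limit of the assay and not a number. For the measured compounds named here, compound 2, with the structure `CC(O)(C(=O)Nc1ccc(S(=O)(=O)N2CCOCC2)cc1)C(F)(F)F`, gives 5850 nM in this assay, and it therefore stands as the only finished number among the two values shown.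

Compound 3, with the structure `CN(C)S(=O)(=O)c1ccc(NC(=O)C(C)(O)C(F)(F)F)cc1`, keeps the core of compound 2 and differs from it in one place: dimethylamino in place of morpholin-4-yl on a sulfonyl sulfur. No measured pair among the compounds shown has this same change, so there is no measured step to lean on. The expectation for the step from compound 2 to compound 3 in this assay is a move of a 1.0-fold higher number from compound 2 to compound 3 (0.01 log units; within the scatter), which is no more than the usual scatter in either direction. On that basis compound 3 is estimated to give 6000 nM in this assay, with a likely range from 2000 nM to 20000 nM.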

Compound 3, half-maximal inhibitory concentration: 480 nM
For compound 3 the middle estimate is 13-fold (1.10 log units) above the measured one, outside the stated range (below it).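

In this assay the group on the sulfonyl sulfur proves to matter: dimethylamino in place of morpholin-4-yl gives a 12-fold lower number from compound 2 to compound 3 (1.09 log units; beyond the scatter), a large step well beyond the scatter. For the compounds shown here, until now only one finished number was available for this kind of sulfonyl compound, so nothing showed whether a change at this place could move the read-out; this pair shows that it can, and that here the open group with no ring and fewer heavy atoms goes with the stronger inhibitor. This is a single pair, so it describes these two compounds only, and nothing measured here explains why the number drops.

From the compounds shown here alone, what stays open is which part of the change carries the step: the loss of the ring or the loss of the ring oxygen. A piperidine ring, which keeps the ring without that oxygen, would help separate the two, while a diethylamino or methylamino group on the same sulfur would show how far the open amine can be varied.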